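The compounds below may be only part of what the source reports. "The series", "measured", "known", "first", "only" and "open" are said of these compounds alone.

Measured in a functional assay on the whole organism (strain Wistar) with Rattus norvegicus as the target, with a stated time of 15 days, at a dose of 10 mg/kg by the oral route; on this read-out higher numbers stand for a stronger effect at the one dose given and lower numbers for a weaker effect:

Compound 1 `Cc1ccc(-c2nnc(SCCOc3ccc(/C=C4\SC(=O)NC4=O)cc3)[nH]2)cc1`: 21.7%
Compound 2 `O=C1NC(=O)/C(=C/c2ccc(OCCSc3nnc(-c4ccc([N+](=O)[O-])cc4)[nH]3)cc2)S1`: 15.3%
Compound 3 `O=C1NC(=O)/C(=C/c2ccc(OCCSc3nnc(-c4ccccc4[N+](=O)[O-])[nH]3)cc2)S1`: 20.9%

On these numbers compound 3 stands second highest of the three, but neither neighbour is separated from it by more than the scatter: the step of a number 0.8 percentage points lower from compound 1 to compound 3 (within the scatter) is small, and so is the step of a number 5.6 percentage points higher from compound 2 to compound 3 (within the scatter). The three compounds share one core and differ only in the group carried on an aromatic carbon of a five-membered aromatic ring with 3 nitrogen.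

Compound 4 `O=C1NC(=O)/C(=C/c2ccc(OCCSc3nnc(-c4ccc(Br)cc4)[nH]3)cc2)S1` keeps that core and changes the same group: 4-bromophenyl in place of 2-nitrophenyl on an aromatic carbon.

All three measured steps bear on this change, since each of them exchanges the group at this very position. The step of a number 6.4 percentage points lower from compound 1 to compound 2 (within the scatter), the step of a number 0.8 percentage points lower from compound 1 to compound 3 (within the scatter) and the step of a number 5.6 percentage points higher from compound 2 to compound 3 (within the scatter) all stay within the scatter, so on the evidence in hand exchanges at this place have not moved the read-out in this assay by more than noise. A bromophenyl has not been tried, so a step beyond the scatter cannot be excluded, but none is indicated.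

Compound 4 is therefore expected to give about 20% in this assay, within a range from 10% to 30%. The expected step is a number 0.9 percentage points lower from compound 3 to compound 4 (within the scatter), nothing beyond the scatter.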

Compound 4, a percentage reported as activity, at one dose (the size of the read-out at that dose, not a potency): 26.9%
The estimate for compound 4 lay 6.9 percentage points below the measured number; low and high end bracket the measured number.
By their numbers in this assay, from the lowest: compounds 2, 3, 1 and 4 (each within the scatter of the next, the first and the last beyond it).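

In this assay, this position on an aromatic carbon of the five-membered aromatic ring with 3 nitrogen now gives its first step beyond the scatter: a number 11.6 percentage points higher from compound 2 to compound 4 (beyond the scatter), with bromo in place of nitro. The other two steps, a number 6 percentage points higher from compound 3 to compound 4 (within the scatter) and a number 5.2 percentage points higher from compound 1 to compound 4 (within the scatter), stay within the scatter, so 4-bromophenyl separates from the 4-nitrophenyl of compound 2 but not from the 2-nitrophenyl of compound 3 or the 4-methylphenyl of compound 1, and the exchange at this place matters for that one pair only. Nothing in hand accounts for that single step.

Open, as far as these compounds go, is whether the step beyond the scatter belongs to bromo itself or would also appear with another group on the phenyl ring, such as chloro, an amine or a carboxylic acid. Also open, from the compounds shown here alone, is whether a group without a phenyl ring at this place, such as cyclohexyl or a longer alkyl chain, stays with these four compounds in this assay.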